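Lengthening the hydroxycarbamoyl chain: compound 3 to compound 4

The source may report more compounds than this note shows. Statements on the series, on what has been measured and on what is new or still open speak of the compounds shown alone.

Compound 1 `CNC(=O)CCCCCCCn1nc(-c2cnc3[nH]ccc3c2)c2c(N)ncnc21` gives 7570 nM (a number)
Compound 2 `Nc1ncnc2c1c(-c1cnc3[nH]ccc3c1)nn2CCCCC(=O)NO` gives > 150000 nM (a limit)
Compound 3 `Nc1ncnc2c1c(-c1cnc3[nH]ccc3c1)nn2CCCCCC(=O)NO` gives > 150000 nM (a limit)

In a functional assay on MCF7 cells (Homo sapiens) for inhibition, read by MTT assay, with a stated time of 72 h (on this read-out lower numbers stand for stronger inhibition and higher numbers for weaker inhibition), compound 3 stands at the limit of > 150000 nM in this assay, at which 2 of the 3 values shown sit, and has only a limit, no number. Compound 4 `Nc1ncnc2c1c(-c1cnc3[nH]ccc3c1)nn2CCCCCCCCCC(=O)NO` carries 4-(hydroxycarbamoyl)butyl in place of hydroxycarbamoyl on a saturated chain carbon, five bonds along the chain from an aromatic nitrogen. Among the compounds with values here, two measured steps bear on this change: an at least 19-fold higher number from compound 1 to compound 3 (1.29 log units; beyond the scatter) and an at least 19-fold higher number from compound 1 to compound 2 (1.29 log units; beyond the scatter). Both are large and beyond the scatter, but in each the chain and its end group change together. The third step, a step that the two limits leave unreadable from compound 2 to compound 3, gives no reading. Within the data shown here, compound 1, with its longer chain, is the only compound with a number, so an at least 19-fold higher number from compound 1 to compound 3 (1.29 log units; beyond the scatter) suggests that a longer chain may bring the value down from the limit in this assay. A large fall is therefore expected, though a further limit remains possible. The estimated change is an at least 12-fold lower number from compound 3 to compound 4 (1.09 log units; beyond the scatter). The expected value for compound 4 is 12000 nM (estimated range 2000 nM to 80000 nM).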

Compound 4, half-maximal inhibitory concentration: 23200 nM
Beside the measured number, compound 4's estimate is 1.9-fold (0.29 log units) below it; low and high end bracket the measured number.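

In this assay, within the data shown here, lengthening the chain that ends in hydroxycarbamoyl gives the first number for this end group, with an at least 6.4-fold lower number from compound 3 to compound 4 (0.81 log units; beyond the scatter) and an at least 6.4-fold lower number from compound 2 to compound 4 (0.81 log units; beyond the scatter). Compound 2 and compound 3 remain limits, not numbers: the limit of > 150000 nM in this assay, at which 2 of the 4 values shown sit. Compound 4 still does not match the methylcarbamoyl compound, with a 3.1-fold higher number from compound 1 to compound 4 (0.49 log units; beyond the scatter), although chain length and end group change together in that step, so the end group cannot be judged alone.

The compounds shown leave open at which chain length between those of compound 3 and compound 4 the value first leaves the limit. They also leave open whether a longer chain, or a carboxylic acid in place of hydroxycarbamoyl, would bring the number lower still.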